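The source may hold more compounds than are shown below. What is called first, only, known or untested is meant among the compounds shown, and "the series" means these compounds.

For the measured compounds named here, compound 3, `COc1cccc(-c2nc3ncccc3o2)c1`, was tested in a functional assay on the whole organism for inhibition, with Rattus norvegicus as the target, at a dose of 30 mg/kg (a lower number here means less inhibition, a higher number more inhibition at the dose given (going by the name of the read-out)), where compound 3 gives 14%, the second highest of the three numbers measured so far. Its nearest neighbour is compound 2, `COc1ccc(Br)c(-c2nc3ncccc3o2)c1`, which in this assay gives 8%, and the furthest is compound 1, `Clc1ccc(-c2nc3ncccc3o2)cc1`, which gives 24%; both of these lie within the usual scatter of the number for compound 3. Going by the values given here, the only single-point step among the measured compounds is the one from compound 2 to compound 3, a number 6 percentage points higher from compound 2 to compound 3 (within the scatter), which leaves hydrogen in place of bromo on an aromatic carbon and stays inside the scatter.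

The next compound, compound 4, `O=[N+]([O-])c1cccc(-c2nc3ncccc3o2)c1`, differs from compound 3 in one place: nitro in place of methoxy on an aromatic carbon. Among the compounds with values here, no measured step puts a nitro group in place of a methoxy group, so the one step that is available bears on the new change only loosely, and it was itself small. Compound 3, compound 2 and compound 1 together span a narrow band of numbers. On that basis compound 4 is expected to stay near compound 3, with a step of a number 1 percentage points higher from compound 3 to compound 4 (within the scatter) that is not expected to exceed the scatter. The estimate for compound 4 in this assay is 15%, with a range from 0% to 35%.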

Compound 4, a percentage reported as inhibition, in the whole organism at one dose (the size of the read-out at that dose, not a potency): 21%
Compound 4: the middle estimate sits 6 percentage points below what was measured, within the range that was stated.
By their numbers in this assay, from the lowest: compounds 2, 3, 4 and 1 (each within the scatter of the next, the first and the last beyond it).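

At this position, on an aromatic carbon of a six-membered aromatic ring of carbon only and meta to a group of 9 heavy atoms, this assay gives for nitro in place of methoxy a number 7 percentage points higher from compound 3 to compound 4 (within the scatter). The earlier single-point step changed bromo to hydrogen elsewhere on the ring and left methoxy in place, so this is the first step among the compounds shown that exchanges the methoxy group itself, and it shows that methoxy and nitro, which differ in their heavy atoms and hydrogen-bond acceptors but carry no net charge, cannot be told apart here beyond the scatter. Nothing measured on these compounds offers an explanation for this result.

Going by these compounds, whether an amine or a carboxylic acid on this same aromatic carbon would produce a step beyond the scatter remains open. Also open, on these data alone, is how compound 3 and compound 4 would compare at other doses, since a reading at a single dose is not a measure of potency.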